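Swapping Bromo for Methyl on the Aryl Ring

This account rests on a few compounds, and the source may have more. Where it says the series, first, only, none or still open, it means among the compounds named here.

Compound 1 `O=C1NC(c2ccc(Br)cc2)CN1S(=O)(=O)c1ccc(Cl)cc1` is the starting point. In a functional assay on A549 cells (Homo sapiens) for cytotoxicity (a lower number here means a stronger inhibitor, a higher number a weaker inhibitor), compound 1 gives 161000 nM. Compound 2 `Cc1ccc(C2CNC(=O)N2S(=O)(=O)c2ccc(Cl)cc2)cc1` differs from compound 1 in two places at once, and in this assay compound 2 gives 266000 nM, a value that sits within the usual scatter of that of compound 1. Compound 3 `Cc1ccc(S(=O)(=O)N2CC(c3ccc(Br)cc3)NC2=O)cc1` is reported only as a limit of the assay: in this assay compound 3 gives > 253000 nM. Compound 3 sits at the limit of > 253000 nM in this assay, at which 1 of the 3 values shown sits. Going by the values given here, the single step measured in one place, an at least 1.5-fold higher number from compound 1 to compound 3 (0.19 log units; that floor lies within the scatter), changes the ring that carries the sulfonyl group, and its size is known only as a floor.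

Compound 4 `Cc1ccc(C2CN(S(=O)(=O)c3ccc(Cl)cc3)C(=O)N2)cc1` has not yet been measured. It differs from compound 1 as follows: methyl in place of bromo on an aromatic carbon. Among the compounds with values here, no measured step alters this ring in this way, so the nearest guide is an at least 1.5-fold higher number from compound 1 to compound 3 (0.19 log units; that floor lies within the scatter), together with compound 2 at 266000 nM. A step no larger than the scatter is therefore expected, if anything toward a higher number. For compound 4 the estimated result in this assay is 230000 nM, within 110000 nM to 480000 nM, which amounts to an expected step of a 1.4-fold higher number from compound 1 to compound 4 (0.15 log units; within the scatter).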

Compound 4, half-maximal inhibitory concentration: 158000 nM
Beside the measured number, compound 4's estimate is 1.5-fold (0.16 log units) above it; the measured number falls inside the stated range.
By their numbers in this assay, from the lowest: compounds 4, 1 and 2 (each within the scatter of the next).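

In this assay, the change from 4-bromophenyl to 4-methylphenyl can now be read on its own, and it comes to a 1.0-fold lower number from compound 1 to compound 4 (0.01 log units; within the scatter). Going by these compounds alone, earlier, this ring had changed only in compound 2, together with a second difference, so the one measured single-place step concerned the ring that carries the sulfonyl group. Compound 4 now shows that with the rest of the molecule held fixed, bromo and methyl on this aromatic carbon, para to a large group, cannot be told apart in this assay, and nothing measured here offers a reason for that.

Bromo and methyl each bring a single heavy atom, so it stays open whether an amine, a carboxylic acid or a longer chain in this place would move the number beyond the scatter. Compound 3 remains only a limit of the assay, > 253000 nM, which leaves the true size of the methyl-for-chloro change on the other ring unknown.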